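Moving the chlorine round the ring: compound 3 to compound 4

The compounds below may be only part of what the source reports. "The series", "measured", "known", "first", "only" and "open" are said of these compounds alone.

Of the compounds shown here, three sharing one core have been measured in an ADME assay on MT4 cells (Homo sapiens) for cytotoxicity, read by MTT assay, with a stated time of 4 days; a lower number here means that less compound is tolerated, a higher number that more compound is tolerated. Compound 1 `Cc1cc(-c2ccc(C(F)(F)F)cc2)cc(C)c1Nc1ccnc(Nc2ccc(C#N)cc2)n1` gives 4160 nM. Compound 2 `Cc1cc(-c2ccc(Cl)cc2)cc(C)c1Nc1ccnc(Nc2ccc(C#N)cc2)n1` gives 4190 nM. Compound 3 `Cc1cc(-c2cccc(Cl)c2)cc(C)c1Nc1ccnc(Nc2ccc(C#N)cc2)n1` gives 2160 nM, the smallest of the three numbers, yet both of its gaps sit inside the scatter: a 1.9-fold lower number from compound 1 to compound 3 (0.28 log units; within the scatter) and a 1.9-fold lower number from compound 2 to compound 3 (0.29 log units; within the scatter). Between compound 1 and compound 2 the change was a 1.0-fold higher number from compound 1 to compound 2 (0.00 log units; within the scatter). In short, nothing among these three moves beyond what repeated measurement would show.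

Compound 4 `Cc1cc(-c2ccccc2Cl)cc(C)c1Nc1ccnc(Nc2ccc(C#N)cc2)n1` has not yet been measured. It differs from compound 3 only in where the chlorine sits on the outer ring: 2-chlorophenyl in place of 3-chlorophenyl on an aromatic carbon.

The step that bears most directly on this is the earlier shift of the chlorine from one ring position to another, a 1.9-fold lower number from compound 2 to compound 3 (0.29 log units; within the scatter), together with the swap of a whole substituted ring, a 1.9-fold lower number from compound 1 to compound 3 (0.28 log units; within the scatter). Both were within the scatter. A further shift of the same chlorine is therefore expected to give no step beyond the scatter in this assay, in either direction, with the estimated step being a 1.4-fold higher number from compound 3 to compound 4 (0.14 log units; within the scatter). Compound 4 is estimated to give about 3000 nM, in a range from 1200 nM to 7500 nM.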

Compound 4, half-maximal cytotoxic concentration: 3990 nM
Estimate against measurement, compound 4: 1.3-fold (0.12 log units) below; the measured number falls inside the stated range.
By their numbers in this assay, from the lowest: compounds 3, 4, 1 and 2 (each within the scatter of the next).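

With compound 4, the 2-chlorophenyl group joins the 3-chlorophenyl and 4-chlorophenyl groups, so all three chlorophenyl forms can now be compared in this assay, and moving the chlorine does not carry the number outside the scatter: the readings are a 1.8-fold higher number from compound 3 to compound 4 (0.27 log units; within the scatter) and a 1.1-fold lower number from compound 2 to compound 4 (0.02 log units; within the scatter). Exchanging the 4-(trifluoromethyl)phenyl group for 2-chlorophenyl gives the same picture, with a 1.0-fold lower number from compound 1 to compound 4 (0.02 log units; within the scatter), so across these four compounds, no change at this place on the ring, para to a large group, separates one compound from another in this assay. Nothing in the information available accounts for how close these numbers lie.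

As far as these compounds go, all four outer rings are carbon-only aromatic rings carrying a single chlorine or trifluoromethyl group, so it remains open whether an unsubstituted phenyl, or a phenyl bearing an amine or a carboxylic acid, would also stay within the scatter. From the compounds shown here alone, it is also open whether the insensitivity to the chlorine's placing would hold on a different core, since all four compounds share the same one.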